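A few compounds are considered here, and "the series" means these few. Any claim that something is new, unique, unknown or untested is made for them only; others in the source may bear on it.

Within the data shown here, compound 3 `C[C@H](NC(=O)Nc1ccc(C(C)(C)C)cc1)c1ccccc1` is one of three compounds measured in an ADME assay on the whole organism with Oryza sativa as the target, tested at 0.1 uM (a higher number here means a weaker effect of the compound at the concentration tested, a lower number a stronger effect), where compound 3 gives 100%. Compound 1 `CC(C)c1ccc(NC(=O)N[C@@H](C)c2ccccc2)cc1` gives 98% and compound 2 `CCCc1ccc(NC(=O)N[C@@H](C)c2ccccc2)cc1` gives 97%. The steps of a number 2 percentage points higher from compound 1 to compound 3 (within the scatter) and a number 3 percentage points higher from compound 2 to compound 3 (within the scatter) both lie within the scatter, so compound 3 stands level with the other two, and the three numbers cannot be told apart.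

Compound 4 `CCCCCCc1ccc(NC(=O)N[C@@H](C)c2ccccc2)cc1` differs from compound 3 in the following way: hexyl in place of tert-butyl on an aromatic carbon. Among the measured compounds shown here, two measured steps bear on this, since they also exchange one alkyl group for another on that same aromatic carbon: a number 1 percentage points lower from compound 1 to compound 2 (within the scatter) and a number 3 percentage points higher from compound 2 to compound 3 (within the scatter), both within the scatter. Because the step of a number 3 percentage points higher from compound 2 to compound 3 (within the scatter) lies within the scatter, the expected step for hexyl in place of tert-butyl is a number 1 percentage points lower from compound 3 to compound 4 (within the scatter), none beyond the scatter. Compound 4 is therefore estimated to give 99%, within a range from 90% to 100%.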

Compound 4, a percentage reported as activity, at one concentration (the size of the read-out at that concentration, not a potency): 99%
Estimate against measurement, compound 4: no gap at the digits printed; measured number inside the range.
By their numbers in this assay, from the lowest: compounds 2, 1, 4 and 3 (each within the scatter of the next).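

On this aromatic carbon in this assay, hexyl in place of tert-butyl gives a number 1 percentage points lower from compound 3 to compound 4 (within the scatter), hexyl in place of isopropyl gives a number 1 percentage points higher from compound 1 to compound 4 (within the scatter), and the lengthening of propyl to hexyl gives a number 2 percentage points higher from compound 2 to compound 4 (within the scatter). The four compounds thus show that the read-out stays level from the branched groups to a straight chain as long as hexyl, and that the extra chain length produces no step beyond the scatter. No evidence is available that bears on this result.

On these data alone, all four compounds carry only an alkyl group at this position, so it remains open whether an amine, a carboxylic acid or a methoxy group there would move the read-out beyond the scatter. As far as these compounds go, it also remains open whether a chain longer than hexyl would stay level with these compounds.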